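Sulfonamide chain length and cytotoxicity in a benzamide series

This account rests on a few compounds, and the source may have more. Where it says the series, first, only, none or still open, it means among the compounds named here.

Compound 1, `CCS(=O)(=O)Nc1ccc(NC(=O)c2ccc(Cl)cc2)cc1Cl`: > 250000 nM
Compound 2, `CS(=O)(=O)Nc1ccc(NC(=O)c2ccc(Cl)cc2)cc1F`: 216000 nM

Of the compounds shown here, two have been tested in an ADME assay on HEK293 cells (Homo sapiens) for cytotoxicity, read by MTT assay, with a stated time of 48 h; on this read-out lower numbers stand for stronger inhibition and higher numbers for weaker inhibition. Compound 1 returns only a limit of the assay, > 250000 nM, and no number. Going by the values given here, compound 2 gives 216000 nM and so holds the only numeric value in this assay. The other value on record is the limit of > 250000 nM in this assay, at which 1 of the 2 values shown sits. Compound 3, `CCS(=O)(=O)Nc1ccc(NC(=O)c2ccc(Cl)cc2)cc1F`, remains to be tested in this assay. It differs from compound 2 by methyl in place of hydrogen on a saturated chain carbon bound to a sulfonyl sulfur. Among the compounds with values here, no measured pair is separated by this change alone, so no measured step can be pointed to. The step of a 1.1-fold higher number from compound 2 to compound 3 (0.05 log units; within the scatter) is expected to be none beyond the usual scatter of this assay. Compound 3 is expected to give 240000 nM, in a range from 110000 nM to 500000 nM, with a fair chance that this assay reports only a limit and no number for it.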

Compound 3, half-maximal inhibitory concentration: 53400 nM
Compound 3: the middle estimate sits 4.5-fold (0.65 log units) above what was measured, and the stated range ends above it.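

In this assay, the change from methanesulfonamido to (ethylsulfonyl)amino, with fluoro kept on the aromatic carbon, gives a 4.0-fold lower number from compound 2 to compound 3 (0.61 log units; beyond the scatter), so this read-out responds to a single added methyl on the saturated chain carbon bound to the sulfonyl sulfur. With the ethylsulfonyl group kept, fluoro in place of chloro on the aromatic carbon gives an at least 4.6-fold lower number from compound 1 to compound 3 (0.67 log units; beyond the scatter), which shows that the aromatic halogen also matters in this series. That second step has only one numeric end, as compound 1 is held at a limit of the assay and not at a number: the limit of > 250000 nM in this assay, at which 1 of the 3 values shown sits.

As far as these compounds go, whether the trend along the sulfonyl chain continues with a propyl group or a longer chain, or changes with an amine at the chain end, stays open. The methyl step is read only with fluoro on the aromatic carbon, so its size with chloro there, and the cause of either step, remain unknown.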